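A few compounds are considered here, and "the series" means these few. Any claim that something is new, unique, unknown or untested is made for them only; others in the source may bear on it.

In a functional assay on A549 cells (Homo sapiens) for antiproliferative activity, read by MTT assay, with a stated time of 72 h (on this read-out lower numbers stand for stronger inhibition and higher numbers for weaker inhibition), three compounds have been measured so far. Compound 1 `COc1ccc(N2C(=O)COc3ccc(-c4cnc(Cl)c(NS(=O)(=O)c5ccc(F)cc5)c4)cc32)cc1` gives 30400 nM. Compound 3 `CC(C)N1C(=O)COc2ccc(-c3cccc(NS(=O)(=O)c4ccc(F)cc4)c3)cc21` gives 29400 nM, so the two numbers lie within the scatter of each other and neither can be ranked over the other. Compound 2 `COc1cccc(N2C(=O)COc3ccc(-c4ccc(O)cc4)cc32)c1` returns only a limit of the assay, > 40000 nM, and not a number. Compound 1 therefore stands level with compound 3 among the two true numbers available.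

Compound 4 `O=C1COc2ccc(-c3cnc(Cl)c(NS(=O)(=O)c4ccc(F)cc4)c3)cc2N1c1ccccc1` has not yet been measured in this assay. It keeps the core of compound 1 and differs from it in one place, hydrogen in place of methoxy on an aromatic carbon, para to a large group, so that 4-methoxyphenyl becomes phenyl. Going by the values given here, no measured pair of compounds shows what this change does in this assay, and the expectation rests on compound 1 at 30400 nM as the nearest reference. No step beyond the scatter is expected, although a slightly lower number would not surprise. The expected change is a 1.3-fold lower number from compound 1 to compound 4 (0.10 log units; within the scatter). For compound 4 the estimated value is 24000 nM, with an expected range of 12000 nM to 40000 nM.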

Compound 4, half-maximal inhibitory concentration: 14700 nM
Compound 4: middle estimate off by 1.6-fold (0.21 log units), on the high side; measured number inside the range.
By their numbers in this assay, from the lowest: compounds 4, 3 and 1 (each within the scatter of the next, the first and the last beyond it). At a limit, above all of these: compound 2.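

In this assay, going by these compounds alone, the pair gives the first reading of what a single change does at this position, para to a large group: a 2.1-fold lower number from compound 1 to compound 4 (0.32 log units; beyond the scatter). The earlier compounds shown here differ from one another in more than one place, so they could show no such step, and this one shows that the position responds when 4-methoxyphenyl becomes phenyl, though only modestly. Methoxy is therefore not needed at this position for the activity seen with compound 1, since compound 4 gives 14700 nM without it, but this rests on a single pair on a single core, and the pair does not tell why the number falls.

Compound 2 offers no comparison for this change, as it gives a limit and not a number: the limit of > 40000 nM in this assay, at which 1 of the 4 values shown sits. From the compounds shown here alone, it stays open how this position would answer to a fluorine, a hydroxyl, an amine or a longer chain such as ethoxy, and whether the same change from methoxy to hydrogen would give a step of like size elsewhere on the aromatic ring.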